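This account rests on a few compounds, and the source may have more. Where it says the series, first, only, none or still open, it means among the compounds named here.

In a functional assay (trachea) with Cavia porcellus as the target (on this read-out higher numbers stand for an effect only at larger amounts of compound and lower numbers for an effect already at smaller amounts), compound 3 `CCCn1c(=O)n(C)c(=O)c2c1ncn2CCCN(C)C` gives > 100000 nM, which is a limit of the assay and not a number. Compound 4 `CCCn1c(=O)n(C)c(=O)c2c1ncn2CCCO` differs from it in one place (hydroxy in place of dimethylamino on a saturated chain carbon, three bonds along the chain from an aromatic nitrogen), with hydroxy in place of dimethylamino on a saturated chain carbon, three bonds along the chain from an aromatic nitrogen. Among the measured compounds shown here, no measured compound carries hydroxy, so the guidance is indirect.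

Compound 1 `CCCn1cnc2c1c(=O)n(C)c(=O)n2CCC` gives 5000 nM, and compound 2 `C=CCCn1cnc2c1c(=O)n(C)c(=O)n2CCC` gives 16800 nM. The closest guide is the large step of an at least 20-fold higher number from compound 1 to compound 3 (1.30 log units; beyond the scatter), where dimethylamino replaces hydrogen at that same place. Two further steps, a 3.4-fold higher number from compound 1 to compound 2 (0.53 log units; beyond the scatter) and an at least 5.9-fold higher number from compound 2 to compound 3 (0.77 log units; beyond the scatter), show that changes at the end of this chain move the number by a modest amount or more.

Losing dimethylamino might therefore recover part of that large step, so a modest move to a lower number is expected in this assay, though compound 4 could also stay at the limit. The expected change is an at least 2.5-fold lower number from compound 3 to compound 4 (0.39 log units; beyond the scatter). For compound 4, the estimated value is 40000 nM, with an expected range from 12000 nM to 100000 nM.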

Compound 4, half-maximal effective concentration: 22600 nM
Compound 4: middle estimate off by 1.8-fold (0.25 log units), on the high side; low and high end bracket the measured number.
By their numbers in this assay, from the lowest: compound 1; then compounds 2 and 4 (each within the scatter of the next). At a limit, above all of these: compound 3.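

In this assay compound 3 gives > 100000 nM, which is a limit of the assay and not a number. Hydroxy in place of dimethylamino brings back a measurable effect, an at least 4.4-fold lower number from compound 3 to compound 4 (0.64 log units; beyond the scatter), so the loss at this chain end goes with dimethylamino and not with the chain itself. Even so, hydroxy in place of hydrogen still leaves a weaker result, a 4.5-fold higher number from compound 1 to compound 4 (0.66 log units; beyond the scatter), while hydroxymethyl in place of vinyl makes no difference that can be told from the scatter, a 1.3-fold higher number from compound 2 to compound 4 (0.13 log units; within the scatter).

The compounds shown leave open what a carboxylic acid, a primary amine or a longer chain ending in hydroxy would do at this place. As far as these compounds go, the full size of the step away from dimethylamino also stays open, as only its minimum can be read.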